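The source may hold more compounds than are shown below. What is called first, only, known or untested is meant among the compounds shown, and "the series" means these compounds.

Compound 1 `CCC(C)n1ncn(-c2ccc(N3CCN(c4ccc(OC[C@@H]5CO[C@@](Cn6cnc(C(F)(F)F)n6)(c6ccc(Cl)cc6Cl)O5)cc4)CC3)cc2)c1=O` is the reference point of this comparison. Among the compounds with values here, in a functional assay on HUVEC cells (Homo sapiens), read by scintillation counting and thymidine incorporation, with a stated time of 24 h (on this read-out lower numbers stand for stronger inhibition and higher numbers for weaker inhibition), compound 1 gives 270 nM, the highest of the two numbers measured so far; compound 2 `CCC(C)n1ncn(-c2ccc(N3CCN(c4ccc(OC[C@@H]5CO[C@@](Cn6ncnn6)(c6ccc(Cl)cc6Cl)O5)cc4)CC3)cc2)c1=O` gives 124 nM. Within the data shown here, the only measured step between these two is a 2.2-fold lower number from compound 1 to compound 2 (0.34 log units; beyond the scatter), which places 2H-tetrazol-2-yl in place of 3-(trifluoromethyl)-1H-1,2,4-triazol-1-yl on a saturated chain carbon bound to a saturated ring carbon.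

Compound 3 `CCC(C)n1ncn(-c2ccc(N3CCN(c4ccc(OC[C@@H]5CO[C@@](Cn6nnnc6-c6ccccc6)(c6ccc(Cl)cc6Cl)O5)cc4)CC3)cc2)c1=O` has not been measured in this assay. It differs from compound 1 by 5-phenyl-1H-tetrazol-1-yl in place of 3-(trifluoromethyl)-1H-1,2,4-triazol-1-yl on a saturated chain carbon bound to a saturated ring carbon. The step from compound 1 to compound 2 bears on this change, since it also exchanges the ring at that place, and it was modest. A tetrazole enters here too, though carrying a phenyl, so a modest step in the same direction is expected, a 1.4-fold lower number from compound 1 to compound 3 (0.13 log units; within the scatter). Compound 3 is therefore estimated at 200 nM, within a range of 70 nM to 600 nM.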

Compound 3, half-maximal inhibitory concentration: 119 nM
Beside the measured number, compound 3's estimate is 1.7-fold (0.23 log units) above it; the measured number falls inside the stated range.
By their numbers in this assay, from the lowest: compounds 3 and 2 (each within the scatter of the next); then compound 1.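

In this assay, the place on a saturated chain carbon bound to a saturated ring carbon tolerates a bigger group: 5-phenyl-1H-tetrazol-1-yl, with 11 heavy atoms against 9 in the group it replaces, gives a 2.3-fold lower number from compound 1 to compound 3 (0.36 log units; beyond the scatter). The two tetrazole groups cannot be told apart here, with a 1.0-fold lower number from compound 2 to compound 3 (0.02 log units; within the scatter), even though only one of them carries a phenyl ring. Both tetrazole compounds therefore lie beyond the scatter from compound 1 with its 3-(trifluoromethyl)-1H-1,2,4-triazol-1-yl group, although three compounds are too few to make this a general rule.

No measurement shown here explains these numbers. Going by these compounds, it also remains open how the number would respond to a methyl group on the tetrazole, or to an amine or a carboxylic acid on its phenyl ring.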